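A few compounds are considered here, and "the series" means these few. Any claim that something is new, unique, unknown or untested is made for them only; others in the source may bear on it.

Three members of the series have been run in an ADME assay on MT4 cells (Homo sapiens) for cytotoxicity, read by MTT assay, with a stated time of 5 days; on this read-out lower numbers stand for higher toxicity in this test and higher numbers for lower toxicity in this test. Compound 1 `Cc1cc(/C=C/C#N)cc(C)c1Oc1nc(Nc2ccc(CN3CCN(S(N)(=O)=O)CC3)cc2)nc2ccsc12` gives 145000 nM. Compound 2 `Cc1cc(/C=C/C#N)cc(C)c1Oc1nc(Nc2ccc(CN3CCNCC3)cc2)nc2ccsc12` gives 3970 nM. Compound 3 `Cc1cc(/C=C/C#N)cc(C)c1Oc1nc(Nc2ccc(N3CCCC(N)C3)cc2)nc2ccsc12` gives 3820 nM. Compound 3 therefore holds the lowest of the three numbers: the nearest is a 1.0-fold lower number from compound 2 to compound 3 (0.02 log units; within the scatter), the furthest is a 38-fold lower number from compound 1 to compound 3 (1.58 log units; beyond the scatter).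

Compound 4 `Cc1cc(/C=C/C#N)cc(C)c1Oc1nc(Nc2ccc(N3CCCC(NS(C)(=O)=O)C3)cc2)nc2ccsc12` carries methylsulfonyl in place of hydrogen on an amine nitrogen. Among the measured compounds shown here, the one measured step that bears on this is a 37-fold lower number from compound 1 to compound 2 (1.56 log units; beyond the scatter), read in the opposite direction: taking a sulfamoyl off an amine nitrogen in a ring gave a much lower number, so putting a methylsulfonyl onto an amine nitrogen is expected to give a higher one. That step concerns sulfamoyl on (4-sulfamoylpiperazin-1-yl)methyl rather than methylsulfonyl on 3-aminopiperidin-1-yl, and the number of hydrogen-bond donors differs, so the size carries uncertainty; the step of a 1.0-fold lower number from compound 2 to compound 3 (0.02 log units; within the scatter) shows the two ring arrangements behave alike without such a group. In this assay a step well beyond the scatter towards a higher number is expected, a 10-fold higher number from compound 3 to compound 4 (1.02 log units; beyond the scatter). Compound 4 is estimated at 40000 nM, within a range from 8000 nM to 200000 nM.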

Compound 4, half-maximal cytotoxic concentration: > 217000 nM
Compound 4 ended at the assay's limit (the forecaster's own chance of this, stated with the estimate: 25%); middle value at least 5.4-fold (0.73 log units) away from the limit.
By their numbers in this assay, from the lowest: compounds 3 and 2 (each within the scatter of the next); then compound 1. At a limit, above all of these: compound 4.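

On the amine nitrogen of 3-aminopiperidin-1-yl itself, methylsulfonyl in place of hydrogen gives, in this assay, an at least 56-fold higher number from compound 3 to compound 4 (1.75 log units; beyond the scatter), so the effect of a group on this nitrogen is now read directly and no longer borrowed from the piperazine pair. Compound 4 stands at a limit of the assay, so the step is a floor and not a size: the limit of > 217000 nM in this assay, at which 1 of the 4 values shown sits.

The comparison with the free piperazine gives the same picture, an at least 54-fold higher number from compound 2 to compound 4 (1.73 log units; beyond the scatter), whereas an at least 1.4-fold higher number from compound 1 to compound 4 (0.17 log units; that floor lies within the scatter) leaves compound 4 and compound 1 unseparated, so among these four compounds both sulfonyl-bearing side chains sit well clear of both free amines, with none going against this.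

On these data alone, whether the shift needs a sulfonyl group at all stays open; an acetyl group or a simple methyl on the same nitrogen would address that. As far as these compounds go, the full size of the step also stays open.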